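Substituents on the amine nitrogen of a shared core

This account rests on a few compounds, and the source may have more. Where it says the series, first, only, none or still open, it means among the compounds named here.

Measured in a functional assay on L929 cells (Mus musculus) for inhibition; a lower number here means a stronger inhibitor of growth, a higher number a weaker inhibitor of growth:
Compound 1 `NNCc1cc(O)n2nc(N)c([N+](=O)[O-])c2n1` gives 35.2 ug/mL.
Compound 2 `Nc1nn2c(O)cc(CNNc3ccc(F)cc3)nc2c1[N+](=O)[O-]` gives 41.4 ug/mL.
Compound 3 `Nc1nn2c(O)cc(CNNC(N)S)nc2c1[N+](=O)[O-]` gives only a limit, > 50 ug/mL.

Compound 3 therefore has no measured number in this assay; it stands at the limit of > 50 ug/mL in this assay, at which 1 of the 3 values shown sits. The step of a 1.2-fold higher number from compound 1 to compound 2 (0.07 log units; within the scatter) is within the scatter, and the steps of an at least 1.4-fold higher number from compound 1 to compound 3 (0.15 log units; that floor lies within the scatter) and an at least 1.2-fold higher number from compound 2 to compound 3 (0.08 log units; that floor lies within the scatter) are floors that also lie within the scatter. Across compounds 1 to 3, changing the group on the amine nitrogen has not moved the read-out beyond the scatter in either direction.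

Compound 4 `CCSC(N)NCc1cc(O)n2nc(N)c([N+](=O)[O-])c2n1` is the next variation: amino(ethylsulfanyl)methyl in place of (amino(sulfanyl)methyl)amino on an amine nitrogen. Within the data shown here, the steps that bear on it are the two into compound 3, both floors within the scatter, together with the small step between compounds 1 and 2. None of them supports a shift beyond the scatter in this assay, in either direction. Compound 4 is therefore expected at 50 ug/mL, with a range from 25 ug/mL to 100 ug/mL. The step of a number no higher from compound 3 to compound 4 (the limit leaves the size open) is estimated to stay within the scatter, and a further limit rather than a number is expected to remain likely.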

Compound 4, concentration for 50% growth inhibition: > 50 ug/mL
Compound 4: a limit, no number; the forecaster's own chance of this, stated with the estimate: 55%; the middle value sits exactly at the limit.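

In this assay, the amine nitrogen now carries a second sulfur-bearing group that ends in a limit rather than a number: the limit of > 50 ug/mL in this assay, at which 2 of the 4 values shown sit.

Against the two compounds with numbers, the result gives an at least 1.2-fold higher number from compound 2 to compound 4 (0.08 log units; that floor lies within the scatter) and an at least 1.4-fold higher number from compound 1 to compound 4 (0.15 log units; that floor lies within the scatter); these floors show no shift beyond the scatter, but they do not exclude a larger one. The step between the two limits cannot be read, so the exchange of (amino(sulfanyl)methyl)amino for amino(ethylsulfanyl)methyl has no readable size.

Going by these compounds, how far the true values of compound 3 and compound 4 lie past their limits stays open, as does whether any group on this amine nitrogen can move the read-out beyond the scatter. On these data alone, what a carboxylic acid, or a longer chain in place of the ethyl, would give also remains open.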